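The source may report more compounds than this note shows. Statements on the series, on what has been measured and on what is new or still open speak of the compounds shown alone.

Measured in a functional assay on MCF7 cells (Homo sapiens) for antiproliferative activity; on this read-out lower numbers stand for stronger inhibition of growth and higher numbers for weaker inhibition of growth:
- compound 1 `COc1ccc(-c2nc3cc(F)ccc3s2)cc1`: 490 nM
- compound 2 `COc1ccc(-c2nc3cc(F)ccc3s2)cc1C`: 48 nM
- compound 3 `COc1ccc(-c2nc3cc(F)ccc3s2)cc1Cl`: 760 nM

Compound 1 sits at the high end of these numbers, and the chloro change leaves it within the scatter: a 1.6-fold higher number from compound 1 to compound 3 (0.19 log units; within the scatter). The methyl change is large: a 10-fold lower number from compound 1 to compound 2 (1.01 log units; beyond the scatter). Exchanging methyl for chloro is also large: a 16-fold higher number from compound 2 to compound 3 (1.20 log units; beyond the scatter).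

Compound 4 `COc1ccc(-c2nc3cc(F)ccc3s2)cc1Br` is a new variation on compound 1: bromo in place of hydrogen on an aromatic carbon. Bromo, like chloro, is a halogen, so the chloro step of a 1.6-fold higher number from compound 1 to compound 3 (0.19 log units; within the scatter) is the closest guide, and no change beyond the scatter is expected. The methyl step keeps the lower side of the range wide.

The expected step is a 1.1-fold lower number from compound 1 to compound 4 (0.04 log units; within the scatter).

For compound 4 the estimated value is 450 nM, with an expected range of 90 nM to 1500 nM.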

Compound 4, concentration for 50% growth inhibition: 850 nM
Estimate against measurement, compound 4: 1.9-fold (0.28 log units) below, and the stated range covers the measured number.
By their numbers in this assay, from the lowest: compound 2; then compounds 1, 3 and 4 (each within the scatter of the next).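

In this assay, bromo on this aromatic carbon, ortho to a methoxy group, stays within the scatter of both hydrogen (a 1.7-fold higher number from compound 1 to compound 4 (0.24 log units; within the scatter)) and chloro (a 1.1-fold higher number from compound 3 to compound 4 (0.05 log units; within the scatter)). With two halogens now showing no change beyond the scatter from hydrogen, methyl stands apart among the four groups (an 18-fold higher number from compound 2 to compound 4 (1.25 log units; beyond the scatter)). Nothing measured here explains this split. As far as these compounds go, whether a longer chain such as ethyl keeps the low number of compound 2 remains open, as does the outcome with an amine or a hydroxyl group at this place.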